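Z to E in the cyclic urea pair

The source may hold more compounds than are shown below. What is called first, only, known or untested is meant among the compounds shown, and "the series" means these compounds.

Measured in a functional assay on M21 cells (Homo sapiens) for inhibition, read by sulforhodamine B assay, with a stated time of 48 h; on this read-out higher numbers stand for weaker inhibition and lower numbers for stronger inhibition:
- compound 1 `CCNC(=O)Nc1ccc(/C=C/c2cccc(Cl)c2)cc1`: > 20000 nM (a limit)
- compound 2 `CCNC(=O)Nc1ccc(/C=C\c2cccc(Cl)c2)cc1`: 35000 nM
- compound 3 `O=C1NCCN1c1ccc(/C=C\c2cccc(Cl)c2)cc1`: 27 nM

Compound 3 holds the lowest of the readable numbers, and its nearest neighbour is set by a 1300-fold lower number from compound 2 to compound 3 (3.11 log units; beyond the scatter). The move to compound 4 `O=C1NCCN1c1ccc(/C=C/c2cccc(Cl)c2)cc1` is the two compounds have the same atoms and bonds and differ only in configuration as drawn: 1 of 1 stereo elements differ; a double bond is drawn Z in compound 3 and E in compound 4. For the measured compounds named here, the only measured step of this kind, a step that the limit leaves unreadable from compound 1 to compound 2, gives no usable size or direction. The expectation therefore rests on weak ground. With compound 3 at 27 nM, a higher number in this assay, meaning weaker inhibition, is expected. The expected change is a 74-fold higher number from compound 3 to compound 4 (1.87 log units; beyond the scatter), which would lie beyond the scatter. For compound 4 the estimate is 2000 nM, with an expected range of 150 nM to 20000 nM.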

Compound 4, half-maximal inhibitory concentration: 19000 nM
Compound 4: the middle estimate sits 9.5-fold (0.98 log units) below what was measured; the measured number falls inside the stated range.
By their numbers in this assay, from the lowest: compound 3; then compounds 4 and 2 (each within the scatter of the next).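

In this assay, the double-bond configuration now has a readable size on the 2-oxoimidazolidin-1-yl compounds: a 700-fold higher number from compound 3 to compound 4 (2.85 log units; beyond the scatter), with the Z form giving the lower number. The same configuration change on the (ethylcarbamoyl)amino compounds cannot be read. With the E double bond, 2-oxoimidazolidin-1-yl in place of (ethylcarbamoyl)amino gives an at least 1.0-fold lower number from compound 1 to compound 4 (0.02 log units; that floor lies within the scatter), a floor only, so the large drop seen with the Z double bond is not shown to carry over.

Open: whether this Z and E gap persists with an amine or a carboxylic acid in place of the chloro group.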